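The compounds below may be only part of what the source reports. "The series", "measured", "known", "first", "only" and "open" are said of these compounds alone.

Measured compounds:
- compound 1, `COc1ccc(Cn2c3c(c4ccccc4c2=O)CCOc2ccccc2-3)cc1`: 11000 nM
- compound 2, `COc1ccc(Cn2c3c(c4ccc(C)cc4c2=O)CCOc2ccccc2-3)cc1`: 4560 nM
- compound 3, `COCOc1ccccc1-c1cc2ccccc2c(=O)[nH]1`: 23600 nM

All three values come from a functional assay on A549 cells (Homo sapiens) for cytotoxicity, read by sulforhodamine B assay; on this read-out higher numbers stand for weaker inhibition and lower numbers for stronger inhibition. The difference between the core of compound 1 and the core of compound 3 is not broken down here. Compound 2 carries methyl in place of hydrogen on an aromatic carbon; the step was a 2.4-fold lower number from compound 1 to compound 2 (0.38 log units; beyond the scatter).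

Compound 4, `COCOc1ccccc1-c1cc2cc(C)ccc2c(=O)[nH]1`, is not yet measured. It carries methyl in place of hydrogen on an aromatic carbon. Within the data shown here, this is the same kind of change as the one from compound 1 to compound 2, though the place differs: in compound 2 the ring is part of a fused or bridged system of four rings, in compound 4 of two rings. In this assay, among the measured compounds shown here, a step of similar direction but less certain size is expected for compound 4, a 2.0-fold lower number from compound 3 to compound 4 (0.29 log units; within the scatter), resting on the single earlier step of a 2.4-fold lower number from compound 1 to compound 2 (0.38 log units; beyond the scatter) on a different core. Compound 4 is thus estimated at 12000 nM, between 5000 nM and 30000 nM.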

Compound 4, half-maximal inhibitory concentration: > 100000 nM
Compound 4 ended at the assay's limit; the forecaster's own chance of this, stated with the estimate: 15%; middle value at least 8.3-fold (0.92 log units) from the limit.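

In this assay, methyl in place of hydrogen on an aromatic carbon gave an at least 4.2-fold higher number from compound 3 to compound 4 (0.62 log units; beyond the scatter), so the direction of the change did not carry over from the core of compound 1 to the core of compound 3: the same change on two cores in this assay, a 2.4-fold lower number (0.38 log units; beyond the scatter) from compound 1 to compound 2 and an at least 4.2-fold higher number (0.62 log units; beyond the scatter) from compound 3 to compound 4, at least 10-fold (1.00 log units) apart, beyond the scatter of two such steps. The reading for compound 4, > 100000 nM, is a limit of the assay and not a number. With a single pair on each core, this shows that the earlier step cannot be relied on for the other core, but it does not show why the two steps part.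

On these data alone, whether an amine or a chlorine on the same aromatic carbon would also differ between the two cores stays open. Also open, as far as these compounds go, is how a longer chain in place of the methyl would read on either core.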